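Compound 1 and its unmeasured mirror image

The source may hold more compounds than are shown below. What is called first, only, known or untested is meant among the compounds shown, and "the series" means these compounds.

Values so far in a functional assay on A549 cells (Homo sapiens) for cytotoxicity, read by MTT assay, with a stated time of 48 h; on this read-out higher numbers stand for weaker inhibition and lower numbers for stronger inhibition
compound 1 `COc1cc([C@@H]2C[C@]2(CO)C(=O)Nc2ccccc2Cl)cc(OC)c1OC` gives 4400 nM
compound 2 `CCOC(=O)C1(C(=O)NCc2ccc(F)cc2)CC1c1cc(OC)c(OC)c(OC)c1` gives 29400 nM; 34100 nM (2 entries)
compound 3 `COc1cc([C@@H]2C[C@]2(CO)C(=O)NCc2ccc(C)cc2)cc(OC)c1OC` gives 10500 nM

Compound 1 gives the lowest number of the three. The repeat entries for compound 2, (the several entries of compound 2 in this assay, 29400 nM; 34100 nM (2 entries)), show how closely two readings can agree. Compound 4 `COc1cc([C@H]2C[C@@]2(CO)C(=O)Nc2ccccc2Cl)cc(OC)c1OC` departs from compound 1 in configuration alone: the two compounds have the same atoms and bonds and differ only in configuration as drawn: 2 of 2 stereo elements differ (all stereocentres are inverted: mirror images); a stereocentre at a saturated ring carbon is drawn S in compound 1 and R in compound 4; a stereocentre at a saturated ring carbon is drawn S in compound 1 and R in compound 4. Within the data shown here, no measured pair tests such an inversion. Among the measured compounds shown here, the one measured step, a 2.4-fold higher number from compound 1 to compound 3 (0.38 log units; beyond the scatter), concerns a different change and offers only a rough scale. Since compound 1 sits lowest at 4400 nM, a modest rise is expected rather than a further fall, though the direction is uncertain. The expected change is a 1.8-fold higher number from compound 1 to compound 4 (0.26 log units; within the scatter) in this assay, an estimate only. Compound 4 is expected at 8000 nM, with an estimated range from 2500 nM to 25000 nM.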

Compound 4, half-maximal inhibitory concentration: > 100000 nM
Compound 4: only a limit was reported; the forecaster's own chance of this, stated with the estimate: 5%; middle value at least 12-fold (1.09 log units) from the limit.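

Inverting both stereocentres gives an at least 22-fold higher number from compound 1 to compound 4 (1.35 log units; beyond the scatter) in this assay, a far larger step than the only earlier one, a 2.4-fold higher number from compound 1 to compound 3 (0.38 log units; beyond the scatter). The result for compound 4 is a limit and not a number: the limit of > 100000 nM in this assay, at which 1 of the 4 values shown sits. No atom or bond changes, so the loss of measurable activity traces to configuration alone: the fact that compounds 1 and 4 differ only in the configuration as drawn

The compounds shown leave open what inverting only one of the two stereocentres would do. They also leave open whether the same gap between mirror images would hold with a carboxylic acid in place of the hydroxymethyl group.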